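Hydroxylated phenyl in place of pyridin-4-yl on the hydrazone

This account rests on a few compounds, and the source may have more. Where it says the series, first, only, none or still open, it means among the compounds named here.

Compound 3 `Cc1c(C(=O)N/N=C\c2ccncc2)oc2cccc(O)c12` stands at the edge of a functional assay on PC-3 cells (Homo sapiens) for inhibition; on this read-out lower numbers stand for stronger inhibition and higher numbers for weaker inhibition: in this assay compound 3 gives >= 40000 nM, which is a limit and not a number. Compound 2 `Cc1c(C(=O)N/N=C\c2cccnc2)oc2cccc(O)c12` likewise gives >= 40000 nM in this assay, again a limit. Compound 1 `Cc1c(C(=O)N/N=C\c2c(O)cccc2Cl)oc2cccc(O)c12` gives 18700 nM in this assay. The steps of an at least 2.1-fold higher number from compound 1 to compound 2 (0.33 log units; beyond the scatter) and an at least 2.1-fold higher number from compound 1 to compound 3 (0.33 log units; beyond the scatter) point the same way, whereas a step that the two limits leave unreadable from compound 2 to compound 3 cannot be read because of the limit of >= 40000 nM in this assay, at which 2 of the 3 values shown sit. Compound 4 `Cc1c(C(=O)N/N=C\c2ccc(O)cc2O)oc2cccc(O)c12` differs from compound 3 by 2,4-dihydroxyphenyl in place of pyridin-4-yl on a carbon with a double bond to nitrogen. Because the carbon-only ring of compound 1 gives 18700 nM, compound 4 is expected to reach a measurable number, with an estimated step of an at least 2.0-fold lower number from compound 3 to compound 4 (0.30 log units; that floor lies within the scatter). Compound 4 is therefore estimated at 20000 nM, in a range from 6000 nM to 40000 nM.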

Compound 4, half-maximal inhibitory concentration: 14800 nM
For compound 4 the middle estimate is 1.4-fold (0.13 log units) above the measured one, within the range that was stated.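

On the carbon with a double bond to nitrogen, 2,4-dihydroxyphenyl moves the read-out in this assay off the limit that both pyridine rings leave, with an at least 2.7-fold lower number from compound 3 to compound 4 (0.43 log units; beyond the scatter) and with an at least 2.7-fold lower number from compound 2 to compound 4 (0.43 log units; beyond the scatter). Both steps give only a minimum size: the limit of >= 40000 nM in this assay, at which 2 of the 4 values shown sit A second carbon-only ring carrying hydroxyl groups, without chlorine, lands within the scatter of the first, with a 1.3-fold lower number from compound 1 to compound 4 (0.10 log units; within the scatter). Open remains whether an unsubstituted phenyl ring would also give a measurable number, and whether an amine or a carboxylic acid on the ring could take the place of the hydroxyl groups.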